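A few compounds are considered here, and "the series" means these few. Any claim that something is new, unique, unknown or untested is made for them only; others in the source may bear on it.

Compound 1, `COc1cccc(-c2nc3c(c(C)nn3-c3ccccc3)c(-c3ccccc3O)c2C#N)c1`, is one of three measured compounds. In an ADME assay on BJ cells (Homo sapiens) for cytotoxicity, with a stated time of 72 h (on this read-out higher numbers stand for an effect only at larger amounts of compound and lower numbers for an effect already at smaller amounts), compound 1 reports only a limit, > 23000 nM.
Compound 2, `Cc1nn(-c2ccccc2)c2nc(-c3ccccc3)c(C#N)c(-c3ccccc3O)c12`, is the second. In this assay compound 2 likewise reports only a limit, > 23000 nM.
Compound 3, `CCCc1ccc(-c2nc3c(c(C)nn3-c3ccccc3)c(-c3ccccc3O)c2C#N)cc1`, is the third. In this assay compound 3 gives 22500 nM.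

Among the measured compounds shown here, compound 3 is thus the only compound of the three with an actual number; the other two sit at a limit (the limit of > 23000 nM in this assay, at which 2 of the 3 values shown sit), and its own number lies close to that same limit. The unmeasured compound 4, `Cc1nn(-c2ccccc2)c2nc(-c3ccc4c(c3)CCCC4)c(C#N)c(-c3ccccc3O)c12`, differs from compound 3 in one place: 1,2,3,4-tetrahydronaphthalen-6-yl in place of 4-propylphenyl on an aromatic carbon.

For the measured compounds named here, two measured steps bear on a change of this kind, both leading into compound 3: an at least 1.0-fold lower number from compound 1 to compound 3 (0.00 log units; that floor lies within the scatter) and an at least 1.0-fold lower number from compound 2 to compound 3 (0.00 log units; that floor lies within the scatter). Each is bounded by a limit and its floor lies within the scatter, so neither shows any clear movement. The account therefore expects no step beyond the scatter for compound 4, a 1.0-fold higher number from compound 3 to compound 4 (0.01 log units; within the scatter), and a fair chance that only a limit is reported again. Compound 4 is estimated at 23000 nM, with a range from 11000 nM to 50000 nM.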

Compound 4, half-maximal effective concentration: > 20000 nM
Compound 4 was reported as a limit; the forecaster's own chance of this, stated with the estimate: 60%; the middle value does not contradict the limit.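

Compound 4 reports only a limit, and the steps to it from compound 1, compound 2 and compound 3 cannot be read. The compounds shown leave open whether 1,2,3,4-tetrahydronaphthalen-6-yl in place of 4-propylphenyl changes the number at all in this assay.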